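The source may report more compounds than this note shows. Statements on the series, on what has been measured and on what is new or still open speak of the compounds shown alone.

Compound 1 `O=c1[nH]/c(=N\OCCCc2cccc(F)c2)ccn1[C@@H]1O[C@H](COP(=O)(O)OP(=O)(O)OP(=O)(O)O)[C@@H](O)[C@H]1O` acts in a functional assay on 1321-N1 cells for agonist activity at P2Y purinoceptor 2 (Homo sapiens), read by scintillation counting and inositol phosphate accumulation (on this read-out lower numbers stand for an effect already at smaller amounts and higher numbers for an effect only at larger amounts of compound), at 190 nM, the second highest of the three numbers measured. Compound 3 `O=c1[nH]/c(=N\OCCCc2ccsc2)ccn1[C@@H]1O[C@H](COP(=O)(O)OP(=O)(O)OP(=O)(O)O)[C@@H](O)[C@H]1O` gives 103 nM, and compound 2 `O=c1[nH]/c(=N\OCCCc2cccc([N+](=O)[O-])c2)ccn1[C@@H]1O[C@H](COP(=O)(O)OP(=O)(O)OP(=O)(O)O)[C@@H](O)[C@H]1O` gives 457 nM. The change to compound 4 `O=c1[nH]/c(=N\OCCCc2ccc3ccccc3c2)ccn1[C@@H]1O[C@H](COP(=O)(O)OP(=O)(O)OP(=O)(O)O)[C@@H](O)[C@H]1O` is naphthalen-2-yl in place of 3-fluorophenyl on a saturated chain carbon, three bonds along the chain from an oxygen. Within the data shown here, no measured step brings in a naphthalen-2-yl, so the other exchanges of this group must serve as guide: a 1.8-fold lower number from compound 1 to compound 3 (0.27 log units; within the scatter), a 2.4-fold higher number from compound 1 to compound 2 (0.38 log units; beyond the scatter) and a 4.4-fold lower number from compound 2 to compound 3 (0.65 log units; beyond the scatter). None of these went beyond a modest size, so in this assay a modest step in either direction, or none beyond the scatter, is expected, with a wide range. For compound 4 the expected value is 200 nM, between 60 nM and 650 nM. The step this estimate means is a 1.1-fold higher number from compound 1 to compound 4 (0.02 log units; within the scatter).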

Compound 4, half-maximal effective concentration: 139 nM
For compound 4 the middle estimate is 1.4-fold (0.16 log units) above the measured one; measured number inside the range.
By their numbers in this assay, from the lowest: compounds 3, 4 and 1 (each within the scatter of the next); then compound 2.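

In this assay, the two-ring naphthalen-2-yl in place of the one-ring 3-fluorophenyl gives a 1.4-fold lower number from compound 1 to compound 4 (0.14 log units; within the scatter), and in place of thiophen-3-yl it gives a 1.3-fold higher number from compound 3 to compound 4 (0.13 log units; within the scatter), so this position accepts the larger carbon-only ring system with no step beyond the scatter. Only the change from 3-nitrophenyl stands out, with a 3.3-fold lower number from compound 2 to compound 4 (0.52 log units; beyond the scatter), which leaves compound 2 as the exception among the four. No supporting measurement explains these results. Still open, from the compounds shown here alone, is how an amine or a carboxylic acid on the ring would fare at this position, and whether a longer chain would change the number.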